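Methyl for trifluoromethyl on the benzamide of compound 2

The compounds below may be only part of what the source reports. "The series", "measured", "known", "first", "only" and "open" are said of these compounds alone.

Working notes on the series. In a functional assay on HL-60 cells (Homo sapiens) for antiproliferative activity, with a stated time of 24 h (on this read-out lower numbers stand for stronger inhibition and higher numbers for weaker inhibition), compound 1 `Cc1ccc(C(=O)Nc2sc3c(c2C(N)=O)CCN(Cc2ccc(Cl)cc2Cl)C3)cc1` gives 19900 nM. Compound 2 `NC(=O)c1c(NC(=O)c2ccc(C(F)(F)F)cc2)sc2c1CCN(C(=O)Nc1ccccc1Cl)C2` stands at the limit of > 50000 nM in this assay, at which 1 of the 2 values shown sits. In this assay compound 2 is recorded as > 50000 nM, a limit and not a number. Compound 3 `Cc1ccc(C(=O)Nc2sc3c(c2C(N)=O)CCN(C(=O)Nc2ccccc2Cl)C3)cc1` is compound 2 with methyl in place of trifluoromethyl on an aromatic carbon. Among the compounds with values here, no measured step covers this change, and compound 1 carries the methyl but differs from compound 2 elsewhere as well. The step is expected to be an at least 1.1-fold lower number from compound 2 to compound 3 (0.04 log units; that floor lies within the scatter), small and toward stronger inhibition at most. For compound 3 the estimate is 45000 nM, between 15000 nM and 150000 nM.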

Compound 3, half-maximal inhibitory concentration: 14600 nM
Beside the measured number, compound 3's estimate is 3.1-fold (0.49 log units) above it; the whole stated range lies above it.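

Methyl in place of trifluoromethyl on the aromatic carbon gives an at least 3.4-fold lower number from compound 2 to compound 3 (0.53 log units; beyond the scatter) in this assay and so moves the read-out into a measurable range, the first reading of what this position does with the rest of compound 3 held fixed. Compound 2 carries a limit and not a number, so the step is a floor: the limit of > 50000 nM in this assay, at which 1 of the 3 values shown sits. With 4-methylphenyl held, (2-chlorophenyl)carbamoyl and 2,4-dichlorobenzyl on the ring nitrogen do not separate, with a 1.4-fold lower number from compound 1 to compound 3 (0.13 log units; within the scatter) as the step. Open, going by these compounds, is how a methoxy or an amine on that aromatic carbon would read. Also open, on these data alone, is whether the methyl step carries over to compounds bearing 2,4-dichlorobenzyl.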